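Swapping the aryl on the triazole of compound 2

This account rests on a few compounds, and the source may have more. Where it says the series, first, only, none or still open, it means among the compounds named here.

In a functional assay on SK-N-SH cells (Homo sapiens) for inhibition, read by MTT assay, with a stated time of 72 h, tested at 50 uM (a lower number here means less inhibition of growth, a higher number more inhibition of growth at the concentration tested), compound 2 `C=CCc1ccc(OCc2cn(-c3ccccc3Cl)nn2)c(O)c1` gives 42.8%. Among the three measured compounds this is the second highest number, but both neighbours lie within the scatter: compound 3 `C=CCc1cc(O)c(O)c(CN2CCC(CCO)CC2)c1` gives 40.6%, and compound 1 `C=CCc1cc(O)c(O)c(CN2CCC(CO)CC2)c1` gives 49.4%, each of them within the scatter of the number for compound 2. Within the data shown here, the one measured step, a number 8.8 percentage points lower from compound 1 to compound 3 (within the scatter), concerns a different pair and a different part of the molecule, so it does not bear on the change now at hand.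

Compound 4 `C=CCc1ccc(OCc2cn(-c3ccc(Br)cc3)nn2)c(O)c1` differs from compound 2 in one place: 4-bromophenyl in place of 2-chlorophenyl on an aromatic nitrogen. Among the measured compounds shown here, no measured pair shows what swapping one halogen-bearing phenyl on that nitrogen for another does, so there is no basis to expect a shift beyond the scatter in this assay. Compound 4 is therefore expected to give about 42%, with a likely range from 28% to 56%, a step of a number 0.8 percentage points lower from compound 2 to compound 4 (within the scatter) that is expected to stay within the scatter.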

Compound 4, percent growth inhibition at one concentration: 61.7%
Compound 4: the middle estimate sits 19.7 percentage points below what was measured, outside the stated range (above it).
By their numbers in this assay, from the lowest: compounds 3, 2 and 1 (each within the scatter of the next); then compound 4.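

In this assay, among these compounds, the aryl group on this aromatic nitrogen turns out to matter: the swap to 4-bromophenyl gives a number 18.9 percentage points higher from compound 2 to compound 4 (beyond the scatter) and is the only step so far that leaves the scatter. The two groups match in every count given, with the same number of heavy atoms, no hydrogen-bond donors or acceptors and no net charge, so those counts do not separate them. No available measurement explains the rise.

The step changes two things at once, the halogen and its place on the phenyl, so this single pair cannot show which of them accounts for the difference. A 4-chlorophenyl or a 2-bromophenyl group would separate the two, and a phenyl carrying an amine or a carboxylic acid would test how far this position tolerates groups other than halogens.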